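From ethyl to trifluoromethyl in a cell tolerance test

This account rests on a few compounds, and the source may have more. Where it says the series, first, only, none or still open, it means among the compounds named here.

Of the compounds shown here, three sharing one core have been tested so far in an ADME assay on HEK293 cells (Homo sapiens) for cytotoxicity, read by resazurin assay, with a stated time of 48 h (a higher number here means that more compound is tolerated, a lower number that less compound is tolerated), on the cells. Compound 1 `CS(=O)(=O)Nc1ccc(-c2nc3ccccc3o2)cc1` gives > 100000 nM here, which is a limit of the assay and not a number. Compound 2 `O=S(=O)(Nc1ccc(-c2nc3ccccc3o2)cc1)c1ccc(O)cc1` gives > 100000 nM here, again a limit and not a number. Within the data shown here, compound 3 `CCc1ccc(S(=O)(=O)Nc2ccc(-c3nc4ccccc4o3)cc2)cc1` gives 82000 nM as the only true number of the set, so it is the one firm starting point.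

Compound 4 `O=S(=O)(Nc1ccc(-c2nc3ccccc3o2)cc1)c1ccc(C(F)(F)F)cc1` differs from compound 3 by a single change trifluoromethyl in place of ethyl on an aromatic carbon that puts trifluoromethyl in place of ethyl on an aromatic carbon. Among the measured compounds shown here, two measured steps bear on this: 4-ethylphenyl in place of methyl on a sulfonyl sulfur gave an at least 1.2-fold lower number from compound 1 to compound 3 (0.08 log units; that floor lies within the scatter) and ethyl in place of hydroxy on an aromatic carbon gave an at least 1.2-fold lower number from compound 2 to compound 3 (0.08 log units; that floor lies within the scatter) as its result. Both are only floors, resting on the limit of > 100000 nM in this assay, at which 2 of the 3 values shown sit, and neither is shown beyond the scatter. No step beyond the scatter is therefore expected in this assay for this change, in either direction. The estimate means a 1.2-fold lower number from compound 3 to compound 4 (0.07 log units; within the scatter) as an expected step, not a measured one. For compound 4 the estimated value is 70000 nM with an expected range from 30000 nM to 100000 nM in this test.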

Compound 4, half-maximal cytotoxic concentration: 94000 nM
Compound 4: the middle estimate sits 1.3-fold (0.13 log units) below what was measured; low and high end bracket the measured number.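

In this assay, the change on this aromatic carbon, para to a large group, gives a 1.1-fold higher number from compound 3 to compound 4 (0.06 log units; within the scatter). Among these compounds, this is the first step in the set with a true number at both ends, and it shows that trifluoromethyl, with 4 heavy atoms including 3 fluorine, can stand in place of ethyl, with 2 heavy atoms, without moving the result beyond the scatter. The comparison with the hydroxy group gives an at least 1.0-fold lower number from compound 2 to compound 4 (0.02 log units; that floor lies within the scatter), but that step is only a floor and cannot show how far apart the two compounds truly lie, because one end of it rests on a limit: the limit of > 100000 nM in this assay, at which 2 of the 4 values shown sit.

Ethyl and trifluoromethyl therefore give results within the scatter of each other, but two groups are too few to show a pattern for this position. From the compounds shown here alone, what an amine, a carboxylic acid or a longer chain would do on this aromatic carbon remains open, as does whether any group placed there would bring the number down beyond the scatter.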